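This account rests on a few compounds, and the source may have more. Where it says the series, first, only, none or still open, it means among the compounds named here.

Three compounds were examined in a functional assay on Huh-7 cells (Homo sapiens) for cytotoxicity, read by MTT assay, with a stated time of 72 h; on this read-out higher numbers stand for lower toxicity in this test and lower numbers for higher toxicity in this test. Compound 1 `O=S(=O)(CCCCl)N1CCC2(CC1)OOC1(CCCC1)OO2` gives in this assay only a limit, > 100 ug/mL. Compound 2 `O=S(=O)(CCCCl)N1CCC2(CC1)OOC1(CCCCCC1)OO2` also gives in this assay only a limit, > 100 ug/mL. The difference between the cores of compound 1 and compound 2 is not broken down here. Compound 3 `O=S(=O)(Cc1ccccc1)N1CCC2(CC1)OOC1(CCCC1)OO2` gives in this assay only a limit as well, > 100 ug/mL. Compound 3 arises from compound 1 by the change (phenyl in place of 2-chloroethyl on a saturated chain carbon bound to a sulfonyl sulfur). The step that the two limits leave unreadable from compound 1 to compound 3 stays unreadable because of the limit of > 100 ug/mL in this assay, at which 3 of the 3 values shown sit, so nothing can be said about whether this change raised or lowered toxicity in this test.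

Compound 4 `O=S(=O)(Cc1ccccc1)N1CCC2(CC1)OOC1(CCCCCC1)OO2` has not yet been measured in this assay. It arises from compound 2 by the change (phenyl in place of 2-chloroethyl on a saturated chain carbon bound to a sulfonyl sulfur), which is the same change already made from compound 1 to compound 3, now applied to the core of compound 2. Since all three values seen so far sit at the limit described by the limit of > 100 ug/mL in this assay, at which 3 of the 3 values shown sit, the step from compound 2 to compound 4 in this assay is expected to be a step that the limit leaves unreadable from compound 2 to compound 4, meaning no readable change. Compound 4 is therefore expected to give in this assay about 150 ug/mL, within the range 100 ug/mL to 400 ug/mL, and most probably the assay will again report only a limit rather than a number.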

Compound 4, half-maximal cytotoxic concentration: > 100 ug/mL
Compound 4 ended at the assay's limit (the forecaster's own chance of this, stated with the estimate: 90%); the middle value lies beyond the limit too.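

In this assay compound 4 gives > 100 ug/mL, which is a limit and not a number. Its comparison with compound 2 therefore yields no readable step, and phenyl in place of 2-chloroethyl stays without a size: the limit of > 100 ug/mL in this assay, at which 4 of the 4 values shown sit.

The compounds shown leave open how toxic any of them is beyond this limit, and whether either the core or the side group makes a difference there.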